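A Chloro Substituent on the Isatin Core: Expected Effect

The source may hold more compounds than are shown below. What is called first, only, known or untested is meant among the compounds shown, and "the series" means these compounds.

Among the measured compounds shown here, compound 1 `Cc1ccc2nc(/N=C3\C(=O)N(CN4CCCCC4)c4ccccc43)sc2c1` gives 37800 nM in a functional assay on MCF7 cells (Homo sapiens) for cytotoxicity, read by sulforhodamine B assay, with a stated time of 48 h (on this read-out lower numbers stand for stronger inhibition of growth and higher numbers for weaker inhibition of growth), the highest of the three numbers measured so far. Its nearest neighbour is compound 3 `CCN(CC)CN1C(=O)C(=O)c2c(Cl)cccc21`, which in this assay gives 34100 nM, a number within the scatter of that of compound 1; the furthest is compound 2 `Cc1ccc2nc(/N=C3\C(=O)N(CN(C)C)c4ccccc43)sc2c1`, which gives 29200 nM. For the measured compounds named here, the one step measured between compounds differing in a single place, a 1.3-fold lower number from compound 1 to compound 2 (0.11 log units; within the scatter), lies within the scatter.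

Compound 4 `Cc1ccc2nc(/N=C3\C(=O)N(CN4CCCCC4)c4cccc(Cl)c43)sc2c1` differs from compound 1 by chloro in place of hydrogen on an aromatic carbon. Going by the values given here, no measured step bears directly on this change. Compound 3 carries a chloro on its core, but it lacks the benzothiazolylimino group and carries a diethylamino chain, so its value serves only as a loose reference; its number and that of compound 1 differ by less than the scatter. Among the compounds with values here, the only measured step, from compound 1 to compound 2, was within the scatter and concerned the amine, not the aromatic ring.

On this basis compound 4 is expected to give 32000 nM in this assay, within a range from 12000 nM to 85000 nM. The step this estimate implies, a 1.2-fold lower number from compound 1 to compound 4 (0.07 log units; within the scatter), is expected to stay within the scatter.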

Compound 4, concentration for 50% growth inhibition: 30900 nM
Compound 4: middle estimate off by 1.0-fold (0.02 log units), on the high side, within the range that was stated.
By their numbers in this assay, from the lowest: compounds 2, 4, 3 and 1 (each within the scatter of the next).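

In this assay, chloro in place of hydrogen on an aromatic carbon, ortho to a fused ring and meta to a fused ring, gives a 1.2-fold lower number from compound 1 to compound 4 (0.09 log units; within the scatter) and so leaves compound 1 and compound 4 indistinguishable. This is the first single-place step read on the aromatic ring rather than on the amine, and together with a 1.3-fold lower number from compound 1 to compound 2 (0.11 log units; within the scatter) it means that neither of the two single changes shown, one at the amine and one at this aromatic carbon, moves the number beyond the scatter. No other measurement is available that could say anything further about this change.

The compounds shown leave open whether a different group on this same aromatic carbon, such as methoxy, an amine or a carboxylic acid, would give a step beyond the scatter. They also leave open whether chloro gives a similar result on the other aromatic carbons of that ring, or when it is paired with the dimethylamino chain of compound 2 instead of the piperidin-1-yl chain.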